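Methylamino in Place of Propylsulfanyl, Starting from a Limit

A few compounds are considered here, and "the series" means these few. Any claim that something is new, unique, unknown or untested is made for them only; others in the source may bear on it.

Compound 2 `CCCSc1nc(=O)ccn1[C@@H]1O[C@H](COP(=O)(O)OP(=O)(O)O)[C@@H](O)[C@H]1O` was tested in an in vitro functional assay on 1321-N1 cells for agonist activity at P2Y purinoceptor 6 (Homo sapiens), read by scintillation proximity assay and inositol phosphate accumulation; on this read-out higher numbers stand for an effect only at larger amounts of compound and lower numbers for an effect already at smaller amounts. In this assay compound 2 gives >= 100000 nM, which is a limit of the assay and not a number. Compound 1 `Nc1nc(=O)ccn1[C@@H]1O[C@H](COP(=O)(O)OP(=O)(O)O)[C@@H](O)[C@H]1O` gives >= 100000 nM in this assay, again a limit. The step that the two limits leave unreadable from compound 1 to compound 2 therefore cannot be read. Compound 3 `CSc1nc(=O)ccn1[C@@H]1O[C@H](COP(=O)(O)O)[C@@H](O)[C@H]1O` gives > 100000 nM in this assay, also a limit. Compound 4 `CNc1nc(=O)ccn1[C@@H]1O[C@H](COP(=O)(O)OP(=O)(O)O)[C@@H](O)[C@H]1O` arises from compound 2 through the change (methylamino in place of propylsulfanyl on an aromatic carbon). Going by the values given here, no measured step gives this change a size, because compound 1 and compound 2 both sit at the limit of >= 100000 nM in this assay, at which 2 of the 3 values shown sit. Compound 4 is expected to give about 100000 nM, with a range from 30000 nM to 300000 nM, most likely again only a limit. The expected step of a number no higher from compound 2 to compound 4 (the limit leaves the size open) is none beyond the scatter.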

Compound 4, half-maximal effective concentration: > 100000 nM
Compound 4 was reported as a limit; the forecaster's own chance of this, stated with the estimate: 85%; the middle value sits exactly at the limit.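

Compound 4 gives > 100000 nM, which is a limit of the assay and not a number. The steps among compound 1, compound 2 and compound 4 therefore cannot be read. From the compounds shown here alone, what these changes do to the effective concentration, if anything, stays open.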